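Removing the ethynyl group from compound 2

The compounds below may be only part of what the source reports. "The series", "measured", "known", "first", "only" and "open" are said of these compounds alone.

Within the data shown here, in a functional assay on B16 cells (Mus musculus) for cytotoxicity, read by MTT assay, with a stated time of 48 h (a lower number here means a stronger inhibitor, a higher number a weaker inhibitor), only two compounds have numbers so far. Compound 1 `C#CC(=O)Nc1cccc(C#C)c1` gives 300 nM and compound 2 `C#CC(=O)Nc1ccc(C#C)cc1` gives 6300 nM as the higher of the two numbers, which makes it the weaker inhibitor of the pair. The gap between them lies beyond the usual scatter, and the data give no cause for it.

Compound 3 `C#CC(=O)Nc1ccccc1` is the next to be read. Among the measured compounds shown here, it follows from compound 2 by hydrogen in place of ethynyl on an aromatic carbon as the only structural change. For the measured compounds named here, no measured pair yet shows what this change does on its own, so the expectation rests on thin ground. Compound 2 at 6300 nM already stands at the weak end of the measured numbers, and no clear direction can be argued from two values. The estimated change is a 1.3-fold lower number from compound 2 to compound 3 (0.10 log units; within the scatter) and is expected to stay within the scatter in this assay without a firm direction. Compound 3 is expected at 5000 nM with an estimated range from 1200 nM to 20000 nM on present evidence.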

Compound 3, half-maximal inhibitory concentration: 6200 nM
Compound 3: the middle estimate sits 1.2-fold (0.09 log units) below what was measured, and the stated range covers the measured number.
By their numbers in this assay, from the lowest: compound 1; then compounds 3 and 2 (each within the scatter of the next).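

In this assay, among these compounds, the ethynyl group on the aromatic carbon para to a group of 5 heavy atoms gives way to hydrogen with no step that can be told from the scatter (a 1.0-fold lower number from compound 2 to compound 3 (0.01 log units; within the scatter)), so at this place the numbers show no contribution from ethynyl. The same exchange at the place ethynyl holds in compound 1 gives a large step (a 21-fold higher number from compound 1 to compound 3 (1.32 log units; beyond the scatter)), so among these compounds the replacement has no single size: its effect on the number differs with the place on the ring, and only the ethynyl of compound 1 is tied to a step beyond the scatter. No measurement at hand accounts for the difference between these two steps.

On these data alone, it remains open whether a methyl group, a chlorine atom or an amine at the place ethynyl holds in compound 1 would keep the lower number, or whether a longer chain ending in a triple bond would do so. As far as these compounds go, the amide part with its triple bond is the same in all three compounds, so what a saturated propionyl group there would do also stays open.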